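Swapping a carbonyl linker for an ethenyl bridge

The source may report more compounds than this note shows. Statements on the series, on what has been measured and on what is new or still open speak of the compounds shown alone.

Of the compounds shown here, three sharing one core have been measured in an assay on mitochondria (strain BALB/c) for inhibition of glycerol-3-phosphate acyltransferase 1, mitochondrial (Mus musculus), read by scintillation counting, with a stated time of 10 min; a lower number here means a stronger inhibitor, a higher number a weaker inhibitor. Compound 1 `CCCCCCCCS(=O)(=O)Nc1ccc(-c2ccc(OC)cc2)cc1C(=O)O` gives 19500 nM, compound 2 `CCCCCCCCS(=O)(=O)Nc1ccc(-c2ccccc2F)cc1C(=O)O` gives 34600 nM, and compound 3 `CCCCCCCCS(=O)(=O)Nc1ccc(C(=O)c2ccccc2OC)cc1C(=O)O` gives 59200 nM. Among the compounds with values here, compound 3 thus shows the highest of the three numbers, although its gap to compound 2 lies within the scatter and only the step of a 3.0-fold higher number from compound 1 to compound 3 (0.48 log units; beyond the scatter) reaches beyond it.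

Compound 4 `CCCCCCCCS(=O)(=O)Nc1ccc(/C=C/c2ccc(OC)cc2)cc1C(=O)O` has not yet been measured. It differs from compound 3 in one place: 2-(4-methoxyphenyl)ethenyl in place of (2-methoxyphenyl)carbonyl on an aromatic carbon. The group that enters carries the same 4-methoxyphenyl that sits in compound 1, now joined through an ethenyl bridge rather than attached directly.

Within the data shown here, two measured steps bear on this change. The step of a 3.0-fold higher number from compound 1 to compound 3 (0.48 log units; beyond the scatter) and the step of a 1.7-fold higher number from compound 2 to compound 3 (0.23 log units; within the scatter) both point the same way: replacing a directly attached aryl group with the (2-methoxyphenyl)carbonyl gave higher numbers. Reversing that exchange, and returning to the 4-methoxyphenyl of compound 1, is therefore expected to bring the number back down, by about a 3.0-fold lower number from compound 3 to compound 4 (0.47 log units; beyond the scatter), with the new ethenyl bridge adding uncertainty.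

Compound 4 is estimated to give 20000 nM in this assay, most likely between 7000 nM and 60000 nM.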

Compound 4, half-maximal inhibitory concentration: 37100 nM
Compound 4: middle estimate off by 1.9-fold (0.27 log units), on the low side; the measured number falls inside the stated range.
By their numbers in this assay, from the lowest: compounds 1, 2, 4 and 3 (each within the scatter of the next, the first and the last beyond it).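

The exchange in this assay gives a 1.6-fold lower number from compound 3 to compound 4 (0.20 log units; within the scatter) and so does not clearly undo the earlier gap between the directly attached 4-methoxyphenyl and the (2-methoxyphenyl)carbonyl group. Placing the ethenyl bridge into the 4-methoxyphenyl attachment gives a 1.9-fold higher number from compound 1 to compound 4 (0.28 log units; within the scatter) and, set against the 2-fluorophenyl group, the same entering group gives a 1.1-fold higher number from compound 2 to compound 4 (0.03 log units; within the scatter) so neither step can be told apart from ordinary repeat variation. Compound 4 thus adds a third kind of link at this aromatic carbon, para to a large group and meta to a carboxy group, and it lies within the scatter of all three earlier compounds, even though compound 1 and compound 3 lie beyond the scatter of each other.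

Still open, on these data alone, is what a different kind of group would do here, such as an amine, a hydroxyl or a saturated ethyl bridge in place of the ethenyl, and whether any group at this position can shift the number well beyond the scatter. No measurement of any property of these groups is at hand to account for the numbers.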